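The source may report more compounds than this note shows. Statements on the series, on what has been measured and on what is new or still open speak of the compounds shown alone.

Compound 1 `Cc1cc(C)cc(Cc2ccc3c(NCCCNCc4ccco4)ccnc3c2)c1`: 23 10^-6 cm/s
Compound 2 `CC(C)(C)c1ccc(-c2ccc3c(NCCCNCc4ccco4)ccnc3c2)cc1`: 237 10^-6 cm/s
Compound 3 `COc1ccc(-c2ccc3c(NCCCNCc4ccco4)ccnc3c2)cc1`: 237 10^-6 cm/s

In an ADME assay for permeability, using PAMPA, with a stated time of 30 min, at pH 7.4 (on this read-out higher numbers stand for higher permeability and lower numbers for lower permeability), compound 1 has the lowest of the three numbers. The steps of a 10-fold higher number from compound 1 to compound 2 (1.01 log units; beyond the scatter) and a 10-fold higher number from compound 1 to compound 3 (1.01 log units; beyond the scatter) are both large and both beyond the scatter.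

Compound 4 `FC(F)(F)c1cccc(Cc2ccc3c(NCCCNCc4ccco4)ccnc3c2)c1` differs from compound 1 in one place: 3-(trifluoromethyl)phenyl in place of 3,5-dimethylphenyl on a saturated chain carbon bound to an aromatic carbon. Within the data shown here, no measured step matches this change. Both large steps from compound 1 replace 3,5-dimethylbenzyl with a substituted phenyl, a different kind of change. The step of no change at the digits printed from compound 2 to compound 3 (within the scatter) shows that exchanging one substituent on that outer ring for another left the number unchanged. Compound 4 is therefore expected to stay near compound 1, with a 1.3-fold higher number from compound 1 to compound 4 (0.12 log units; within the scatter) within the scatter. The estimate for compound 4 is 30 10^-6 cm/s, from 10 10^-6 cm/s to 90 10^-6 cm/s.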

Compound 4, apparent permeability: 23 10^-6 cm/s
Estimate against measurement, compound 4: 1.3-fold (0.12 log units) above; the measured number falls inside the stated range.
By their numbers in this assay, from the lowest: compounds 1 and 4 (each within the scatter of the next); then compounds 2 and 3 (each within the scatter of the next).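

The earlier compounds shown here showed no change at this place, on a saturated chain carbon bound to an aromatic carbon. In this assay, 3-(trifluoromethyl)phenyl in place of 3,5-dimethylphenyl gives no change at the digits printed from compound 1 to compound 4 (within the scatter), so this exchange of one ring substituent pattern for another leaves the read-out where it was. No measurement shown gives a reason for this result. The compounds shown leave open whether a ring carrying an amine or a carboxylic acid, or a longer chain in place of the ring, would move the number at this place.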